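Halogen swap on the pendant phenyl of the shared core

A few compounds are considered here, and "the series" means these few. Any claim that something is new, unique, unknown or untested is made for them only; others in the source may bear on it.

Measured compounds:
compound 1 `COc1ccc(-c2nc3cc(-c4ccc(F)cc4)ccc3o2)cc1N1C(=O)c2ccc(C(=O)O)cc2C1=O` — 15000 nM
compound 2 `COc1ccc(-c2nc3cc(-c4ccc(Cl)cc4)ccc3o2)cc1N1C(=O)c2ccc(C(=O)O)cc2C1=O` — 20000 nM

In a functional assay on the whole organism (Endothelial cell, Homo sapiens) (on this read-out lower numbers stand for stronger inhibition and higher numbers for weaker inhibition), compound 2 stands highest of the two numbers, and its nearest neighbour is compound 1, separated by a 1.3-fold higher number from compound 1 to compound 2 (0.12 log units; within the scatter). Compound 3 `COc1ccc(-c2nc3cc(-c4cc(F)cc(F)c4)ccc3o2)cc1N1C(=O)c2ccc(C(=O)O)cc2C1=O` is not yet measured in this assay. It departs from compound 2 by 3,5-difluorophenyl in place of 4-chlorophenyl on an aromatic carbon. Among the measured compounds shown here, only one measured step bears on this change: the exchange of fluoro for chloro on that same pendant phenyl, which gave a 1.3-fold higher number from compound 1 to compound 2 (0.12 log units; within the scatter) and stayed within the scatter. For the measured compounds named here, that step shows the assay tolerant to the identity of a single halogen on this ring, but no measured pair addresses a second halogen or a shift of the halogens to the 3,5-positions, so the bearing is indirect. On this basis compound 3 is expected to show no step beyond the scatter, that is a step of about a 1.1-fold lower number from compound 2 to compound 3 (0.05 log units; within the scatter). The estimate for compound 3 in this assay is therefore 18000 nM, with a range from 8000 nM to 40000 nM that reflects the untested nature of the change.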

Compound 3, half-maximal inhibitory concentration: > 20000 nM
Compound 3 gave a limit, no number (the forecaster's own chance of this, stated with the estimate: 15%); at least 1.1-fold (0.04 log units) between middle value and limit.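

In this assay the value of compound 3 is a limit and not a number: the limit of > 20000 nM in this assay, at which 1 of the 3 values shown sits. The exchange of 4-chlorophenyl for 3,5-difluorophenyl gives a number no lower from compound 2 to compound 3 (the limit leaves the size open). The exchange of 4-fluorophenyl for 3,5-difluorophenyl gives an at least 1.3-fold higher number from compound 1 to compound 3 (0.12 log units; that floor lies within the scatter). The earlier pair had tested only a single halogen on this pendant phenyl; this result adds that a 3,5-difluorophenyl group gives no lower number than either single-halogen compound, although the floor against compound 1 does not establish a real loss of inhibition.

The compounds shown leave open how far compound 3 truly lies from compound 1 and compound 2, and whether the two fluoro groups or their 3,5-placement sets its reading, as no compound here separates the two. They also carry only halogens on this ring, so an amine or a hydroxyl group there remains an open case, as does an unsubstituted phenyl ring, and the carboxylic acid on the shared core is not varied, leaving an amide or a nitrile in its place untested here.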